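Heteroaryl amide variation and dog clearance

The compounds below may be only part of what the source reports. "The series", "measured", "known", "first", "only" and "open" are said of these compounds alone.

Compound 2 `COc1cc(C(=O)NC2(C(=O)N[C@H](C)c3ccc(-n4nc(Cl)c5ccccc54)cc3F)CC2)on1` holds the lowest clearance of the two measured compounds: in an in vivo ADME assay on the whole organism (strain Mongrel) for pharmacokinetics, with Canis familiaris (Canis lupus familiaris) as the target (on this read-out higher numbers stand for fast clearance and lower numbers for slow clearance), compound 2 gives 1.3 mL/min/kg, while compound 1 `C[C@@H](NC(=O)C1(NC(=O)c2cncc(Cl)n2)CC1)c1ccc(-n2nc(Cl)c3ccccc32)cc1F` gives 10.5 mL/min/kg in this assay. Going by the values given here, the one measured step, an 8.1-fold lower number from compound 1 to compound 2 (0.91 log units; beyond the scatter), shows that exchanging the heteroaryl group on the carbonyl carbon can move this read-out well beyond the scatter.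

Compound 3 `Cc1cncc(C(=O)NC2(C(=O)N[C@H](C)c3ccc(-n4nc(Cl)c5ccccc54)cc3F)CC2)c1` differs from compound 2 in the same place: 5-methylpyridin-3-yl in place of 3-methoxy-1,2-oxazol-5-yl on a carbonyl carbon. Among the compounds with values here, no measured step covers this particular exchange, so the expectation rests only on the two measured values that bracket the heteroaryl amide series: compound 1 with 10.5 mL/min/kg and compound 2 with 1.3 mL/min/kg. A number somewhere between the two, nearer the middle of that span, is expected, meaning a step of a 3.1-fold higher number from compound 2 to compound 3 (0.49 log units; beyond the scatter) from compound 2 to compound 3. Compound 3 is therefore estimated at 4 mL/min/kg, within a range of 1.5 mL/min/kg to 11 mL/min/kg.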

Compound 3, clearance: 4.3 mL/min/kg
Estimate against measurement, compound 3: 1.1-fold (0.03 log units) below, and the stated range covers the measured number.
By their numbers in this assay, from the lowest: compound 2; then compound 3; then compound 1.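

In this assay, 5-methylpyridin-3-yl on this carbonyl carbon gives an intermediate read-out, with the change from 3-methoxy-1,2-oxazol-5-yl raising clearance (a 3.3-fold higher number from compound 2 to compound 3 (0.52 log units; beyond the scatter)) and the change from 6-chloropyrazin-2-yl lowering it (a 2.4-fold lower number from compound 1 to compound 3 (0.39 log units; beyond the scatter)). The three groups therefore form three separate levels, with 3-methoxy-1,2-oxazol-5-yl still the lowest. Since 3-methoxy-1,2-oxazol-5-yl and 5-methylpyridin-3-yl each have 7 heavy atoms, heavy-atom count alone does not fix the read-out at this position. The data offer no explanation for these differences.

The compounds shown do not separate the contribution of the ring from that of its substituent. On these data alone, a 3-methyl-1,2-oxazol-5-yl or an unsubstituted pyridin-3-yl group would address that question, and the effect of a carboxylic acid or an amine on the heteroaryl ring remains open.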